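A few compounds are considered here, and "the series" means these few. Any claim that something is new, unique, unknown or untested is made for them only; others in the source may bear on it.

Compound 1 `O=C(c1n[nH]c2ccccc12)N1CCc2nc(COc3ccccc3)oc2C1` gave 68% in a functional assay on HEK293 cells for positive allosteric modulation of metabotropic glutamate receptor 5 (Homo sapiens), read by calcium flux; on this read-out higher numbers stand for larger maximal responses and lower numbers for smaller maximal responses.
Compound 2 `O=C(c1n[nH]c2ccncc12)N1CCc2nc(COc3ccccc3)oc2C1` gave 53% in this assay.

For the measured compounds named here, compound 2 stands lowest of the two measured numbers; the only step measured is a number 15 percentage points lower from compound 1 to compound 2 (beyond the scatter), which was beyond the scatter. Compound 3 `O=C(c1n[nH]c2ncccc12)N1CCc2nc(COc3ccccc3)oc2C1` differs from compound 2 by a group of 9 heavy atoms (6 carbon, 3 nitrogen; one five-membered aromatic ring with 2 hetero atoms, one six-membered aromatic ring with 1 hetero atom) in place of a group of 9 heavy atoms (6 carbon, 3 nitrogen; one five-membered aromatic ring with 2 hetero atoms, one six-membered aromatic ring with 1 hetero atom), on a carbonyl carbon; the two have the same atoms, joined differently. Going by the values given here, no measured step covers this rearrangement directly. Among the compounds with values here, the one step at hand, a number 15 percentage points lower from compound 1 to compound 2 (beyond the scatter), concerned a ring of carbon only giving way to a ring with one hetero atom, not a change of where that hetero atom sits, so it bears on compound 3 only loosely. With no closer comparison available, the step of a number 1 percentage points higher from compound 2 to compound 3 (within the scatter) is expected to be none beyond the scatter, in either direction. Compound 3 is therefore estimated at 54% in this assay, with a range from 40% to 68%.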

Compound 3, largest response reached (reported as percent of maximum), in percent of the reference or control that the assay uses: 73%
For compound 3 the middle estimate is 19 percentage points below the measured one; measured number above the stated range.
By their numbers in this assay, from the lowest: compound 2; then compounds 1 and 3 (each within the scatter of the next).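

In this assay, rearranging the group on the carbonyl carbon, with its atoms unchanged, is enough to shift the maximal response: the step is a number 20 percentage points higher from compound 2 to compound 3 (beyond the scatter). A six-membered aromatic ring with one hetero atom therefore does not lower the response in every arrangement, since the step of a number 5 percentage points higher from compound 1 to compound 3 (within the scatter) puts such a ring in place of the ring of carbon only and stays within the scatter. No available measurement accounts for this difference between the two arrangements. The compounds shown leave open how other placements of the hetero atom in that six-membered ring would read. They also leave open whether a fluorine or a methyl group on that ring would preserve the response seen with compound 3.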